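Notes on the amine substituent step toward compound 4

The source may report more compounds than this note shows. Statements on the series, on what has been measured and on what is new or still open speak of the compounds shown alone.

Three compounds share one core and differ only in the group on the amine nitrogen. Compound 1 `c1ccc2c(c1)CCC2NC1CCN(CCCc2c[nH]c3ccc(-n4cnnc4)cc23)CC1` gives 8.9 nM in an assay on CHO cells for displacement of a labelled ligand from 5-hydroxytryptamine receptor 1D (Homo sapiens); on this read-out lower numbers stand for stronger inhibition and higher numbers for weaker inhibition. Among the measured compounds shown here, compound 2 `C[C@@H](NC1CCN(CCCc2c[nH]c3ccc(-n4cnnc4)cc23)CC1)c1ccccc1` gives 0.4 nM in this assay; the step of a 22-fold lower number from compound 1 to compound 2 (1.35 log units; beyond the scatter) is the only measured change at this position. Compound 3 `CN(Cc1ccc(S(C)(=O)=O)cc1)C1CCN(CCCc2c[nH]c3ccc(-n4cnnc4)cc23)CC1` gives 18 nM in this assay, the highest of the three numbers: compound 1 sits below it by a margin beyond the scatter, and compound 2 sits far below it.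

Compound 4 `CC(C)=CCN(C)C1CCN(CCCc2c[nH]c3ccc(-n4cnnc4)cc23)CC1` is not yet measured. It differs from compound 3 in one place: 2-methylprop-1-en-1-yl in place of 4-(methylsulfonyl)phenyl on a saturated chain carbon bound to an amine nitrogen. For the measured compounds named here, the only measured step at the amine nitrogen, from compound 1 to compound 2, was large and came from one ring-bearing group replacing another; the change here instead removes the ring-bearing group in favour of a short chain, so that step bears on it only loosely and gives no direction. Compound 2 shows that a ring-bearing group can sit well here, while compound 3 shows that not every such group does. Going by the values given here, with no measured precedent for a chain at this place, the step of a 1.4-fold higher number from compound 3 to compound 4 (0.14 log units; within the scatter) is expected to be modest and of uncertain direction. Compound 4 is therefore estimated at 25 nM in this assay, within 6 nM to 100 nM.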

Compound 4, half-maximal inhibitory concentration: 0.5 nM
The estimate for compound 4 lay 50-fold (1.70 log units) above the measured number, outside the stated range (below it).
By their numbers in this assay, from the lowest: compounds 2 and 4 (each within the scatter of the next); then compound 1; then compound 3.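

In this assay, among the compounds shown here, the step of a 36-fold lower number from compound 3 to compound 4 (1.56 log units; beyond the scatter) shows that this place does not depend on a ring-bearing group: 3-methylbut-2-en-1-yl, with no ring and no hydrogen-bond acceptors, replaces 4-(methylsulfonyl)benzyl and gives a number in the range previously seen only with the 1-phenylethyl group. The step of a 1.3-fold higher number from compound 2 to compound 4 (0.10 log units; within the scatter) stays within the scatter, even though methyl(3-methylbut-2-en-1-yl)amino replaces (1-phenylethyl)amino on a saturated ring carbon, while the step of an 18-fold lower number from compound 1 to compound 4 (1.25 log units; beyond the scatter) is large, so an open chain on a tertiary amine nitrogen and a ring-bearing group on a secondary one can both sit at the low end of this series. Nothing available here accounts for the large gap between the 4-(methylsulfonyl)benzyl and 3-methylbut-2-en-1-yl compounds.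

The compounds shown do not separate the contribution of the methylsulfonyl group from that of the benzyl group, and an unsubstituted benzyl on the same amine nitrogen would address this. They also leave open whether the double bond of the chain matters, which a saturated 3-methylbutyl chain would test, and what the methyl on the amine nitrogen contributes.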